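The compounds below may be only part of what the source reports. "The series", "measured", "known", "first", "only" and "open" are said of these compounds alone.

Measured so far in a functional assay on DU-145 cells (Homo sapiens) for antiproliferative activity, read by sulforhodamine B assay, with a stated time of 3 days; a lower number here means a stronger inhibitor of growth, a higher number a weaker inhibitor of growth: compound 1 `CN(C)CC(=O)Nc1cccc(Nc2ncc(F)c(Nc3ccc(F)cc3)n2)c1` gives 1210 nM; compound 2 `O=C(Nc1cccc(Nc2ncc(F)c(Nc3ccc(F)cc3)n2)c1)c1cnccn1` gives 26400 nM.

Of these two numbers, compound 2 has the highest, so it is the weaker inhibitor of growth. Compound 3 `O=C(Nc1nccs1)c1cccc(Nc2ncc(F)c(Nc3ccc(F)cc3)n2)c1` differs from compound 2 in one place: (1,3-thiazol-2-yl)carbamoyl in place of ((pyrazin-2-yl)carbonyl)amino on an aromatic carbon. Within the data shown here, the only measured step, a 22-fold higher number from compound 1 to compound 2 (1.34 log units; beyond the scatter), concerns a different exchange, in which the ((pyrazin-2-yl)carbonyl)amino group entered; it gives no direct guide to what happens when that group is replaced by (1,3-thiazol-2-yl)carbamoyl. Among the measured compounds shown here, with no step bearing on this change, the expected move is small, a 1.8-fold lower number from compound 2 to compound 3 (0.25 log units; within the scatter), and the range is wide. Compound 3 is estimated at 15000 nM, between 3000 nM and 60000 nM.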

Compound 3, concentration for 50% growth inhibition: > 10000 nM
Compound 3 was reported as a limit (the forecaster's own chance of this, stated with the estimate: 10%); the middle value is on the limit's open side.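

In this assay, compound 3 is reported only as a limit, not a number: the limit of > 10000 nM in this assay, at which 1 of the 3 values shown sits. The step from compound 2 therefore cannot be read, and the pyrazine and thiazole amides cannot be ranked against each other. Replacing the (((dimethylamino)methyl)carbonyl)amino group of compound 1 with (1,3-thiazol-2-yl)carbamoyl gives an at least 8.2-fold higher number from compound 1 to compound 3 (0.91 log units; beyond the scatter), so a second aromatic ring-bearing amide at this position also gives weaker growth inhibition than compound 1.

Still open, as far as these compounds go, is whether the dimethylamino group itself matters, and what a plain amine or a carboxylic acid on this aromatic carbon would give.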